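The source may hold more compounds than are shown below. What is called first, only, known or untested is meant among the compounds shown, and "the series" means these compounds.

Compound 1 `Cc1cc(C)nc(NS(=O)(=O)c2ccc(/N=C/c3c(Cl)c4ccccc4oc3=O)cc2)n1` was tested in a functional assay on B16-F10 cells (Mus musculus) for cytotoxicity, read by CCK-8 assay, with a stated time of 48 h (a lower number here means a stronger inhibitor, a higher number a weaker inhibitor), where compound 1 gives 170 nM. Compound 2 `Cc1cc(NS(=O)(=O)c2ccc(/N=C/c3c(Cl)c4ccccc4oc3=O)cc2)no1` differs from compound 1 in one place, (5-methyl-1,2-oxazol-3-yl in place of 4,6-dimethylpyrimidin-2-yl on a sulfonamide nitrogen), and in this assay compound 2 gives 270 nM; the step is a 1.6-fold higher number from compound 1 to compound 2 (0.20 log units; within the scatter). Compound 3 `Cc1cc(C)nc(NS(=O)(=O)c2ccc(/N=C/c3c(Cl)c4cc(C(C)(C)C)cc(C(C)(C)C)c4oc3=O)cc2)n1` carries a core that differs from the core of compound 1 in a way that is not broken down here; in this assay compound 3 gives 220 nM, which lies within the scatter of both compound 1 and compound 2.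

Compound 4 `Cc1cc(NS(=O)(=O)c2ccc(/N=C/c3c(Cl)c4cc(C(C)(C)C)cc(C(C)(C)C)c4oc3=O)cc2)no1` has not yet been measured. It differs from compound 3 by 5-methyl-1,2-oxazol-3-yl in place of 4,6-dimethylpyrimidin-2-yl on a sulfonamide nitrogen, the same change that was made from compound 1 to compound 2, at the same place on the sulfonamide nitrogen. Because that earlier change gave a 1.6-fold higher number from compound 1 to compound 2 (0.20 log units; within the scatter), the expected step from compound 3 to compound 4 is about as small, namely a 1.6-fold higher number from compound 3 to compound 4 (0.20 log units; within the scatter). On this basis compound 4 is estimated to give 350 nM in this assay, most likely between 150 nM and 800 nM.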

Compound 4, half-maximal inhibitory concentration: 240 nM
The estimate for compound 4 lay 1.5-fold (0.16 log units) above the measured number, within the range that was stated.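

In this assay, putting 5-methyl-1,2-oxazol-3-yl in place of 4,6-dimethylpyrimidin-2-yl on the sulfonamide nitrogen gives a 1.1-fold higher number from compound 3 to compound 4 (0.04 log units; within the scatter), so on this second core too the exchange leaves the number where it was, within the usual spread of repeats. Among these compounds, this shows only that the two groups are interchangeable in this assay on these two cores; neither step has a direction that can be trusted, and two pairs of compounds on one cell line set no rule for other cores or other read-outs. The two steps agree with each other, and nothing separates the effect of the change on one core from its effect on the other: the same change on two cores in this assay, a 1.6-fold higher number (0.20 log units; within the scatter) from compound 1 to compound 2 and a 1.1-fold higher number (0.04 log units; within the scatter) from compound 3 to compound 4, 1.5-fold (0.16 log units) apart, within the scatter of two such steps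

The compounds shown leave open whether the sulfonamide nitrogen would tolerate something other than these two rings, such as a plain hydrogen, an acetyl group or a pyridin-2-yl ring. They also leave open whether the same exchange would stay as small if the chlorine on the shared core gave way to an amine.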